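A Dimethylamino End on the Propyl Chain

This account rests on a few compounds, and the source may have more. Where it says the series, first, only, none or still open, it means among the compounds named here.

In a functional assay on K562 cells (Homo sapiens) for antiproliferative activity, read by MTT assay, with a stated time of 48 h (on this read-out higher numbers stand for weaker inhibition and lower numbers for stronger inhibition), compound 1 (`Cn1c(N)c(-c2nc3ccccc3[nH]2)c2nc(C#N)c(C#N)nc21`) gives > 50000 nM as a limit, not a number. In this assay compound 2 (`CCn1c(N)c(-c2nc3ccccc3[nH]2)c2nc(C#N)c(C#N)nc21`) gives > 50000 nM as a limit too. In this assay compound 3 (`CCCn1c(N)c(-c2nc3ccccc3[nH]2)c2nc(C#N)c(C#N)nc21`) likewise gives > 50000 nM as a limit. Compound 3 therefore stands with the other two at the limit of > 50000 nM in this assay, at which 3 of the 3 values shown sit, and no rank can be read among them.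

Compound 4 (`CN(C)CCCn1c(N)c(-c2nc3ccccc3[nH]2)c2nc(C#N)c(C#N)nc21`) changes compound 3 in one place, and the propyl chain becomes 3-(dimethylamino)propyl. The counted difference is dimethylamino in place of hydrogen on a saturated chain carbon, three bonds along the chain from an aromatic nitrogen and the new group stands on a saturated chain carbon, three bonds along the chain from an aromatic nitrogen.

The nearest evidence is the chain series, with a step that the two limits leave unreadable from compound 1 to compound 2 and a step that the two limits leave unreadable from compound 2 to compound 3 and a step that the two limits leave unreadable from compound 1 to compound 3 as its steps. Among the compounds with values here, none of them gives a size to carry forward, and no measured compound carries dimethylamino. Only one direction can be read from a limit, towards lower numbers, so a modest gain is expected, though compound 4 may well stay at the limit. The expected step is an at least 2.5-fold lower number from compound 3 to compound 4 (0.39 log units; beyond the scatter) and it is a rough guess. For compound 4 the estimate is 20000 nM with an expected range from 4000 nM to 50000 nM as its span.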

Compound 4, half-maximal inhibitory concentration: 1730 nM
The estimate for compound 4 lay 12-fold (1.06 log units) above the measured number, and the stated range ends above it.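

Compound 1, compound 2 and compound 3 all rest at a limit, not a number, so the steps among them cannot be read, and only compound 4 comes away from that shared limit: the limit of > 50000 nM in this assay, at which 3 of the 4 values shown sit. In this assay, within the data shown here, dimethylamino on a saturated chain carbon, three bonds along the chain from an aromatic nitrogen, therefore gives the first change with a readable size, an at least 28-fold lower number from compound 3 to compound 4 (1.46 log units; beyond the scatter). Set against the shorter chains, the picture is the same, with an at least 28-fold lower number from compound 2 to compound 4 (1.46 log units; beyond the scatter) and an at least 28-fold lower number from compound 1 to compound 4 (1.46 log units; beyond the scatter), and each of these steps starts from a limit, so it gives only a minimum and the full size stays unknown.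

The compounds shown cannot say whether the dimethylamino end is needed as such, or whether a diethylamino group, a morpholine ring or a hydroxyl group at the end of the same propyl chain would do as well. They also leave open how much the chain length matters, as a 2-(dimethylamino)ethyl or 4-(dimethylamino)butyl chain on the same nitrogen would be needed to test it, and they give no reason for the gain.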